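Methyl added to the 3-fluorophenyl arm of compound 3

A few compounds are considered here, and "the series" means these few. Any claim that something is new, unique, unknown or untested is made for them only; others in the source may bear on it.

Compound 3 `C=CCn1c(=O)/c(=C\c2cccc(F)c2)[nH]c(=O)/c1=C\c1ccccc1OC` gives 19700 nM in a functional assay on A549 cells (Homo sapiens) for cytotoxicity, read by CCK-8 assay, with a stated time of 72 h; on this read-out lower numbers stand for stronger inhibition and higher numbers for weaker inhibition; its nearest neighbour is compound 1 `C=CCn1c(=O)/c(=C\c2cccc(C)c2)[nH]c(=O)/c1=C\c1ccccc1OC`, which gives 22700 nM, and the two values lie within the scatter of each other. Compound 2 `C=CCn1c(=O)/c(=C\c2ccc(Cl)c(Cl)c2)[nH]c(=O)/c1=C\c1ccccc1` is reported as "not active" (no number reported), with no number. Among the compounds with values here, the only single-point step so far, a 1.2-fold lower number from compound 1 to compound 3 (0.06 log units; within the scatter), changes one substituent on the same ring and stays within the scatter.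

Compound 4 `C=CCn1c(=O)/c(=C\c2cc(F)ccc2C)[nH]c(=O)/c1=C\c1ccccc1OC` differs from compound 3 by methyl in place of hydrogen on an aromatic carbon. Within the data shown here, that step is not covered by any measured pair; the one ring-substituent change available was flat. Compound 4 is therefore expected near compound 3, with the step of a 1.0-fold lower number from compound 3 to compound 4 (0.02 log units; within the scatter) inside the scatter. The estimate for compound 4 is 19000 nM, in the range 8000 nM to 50000 nM.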

Compound 4, half-maximal inhibitory concentration: 4900 nM
The estimate for compound 4 lay 3.9-fold (0.59 log units) above the measured number; measured number outside the range, below it.
By their numbers in this assay, from the lowest: compound 4; then compounds 3 and 1 (each within the scatter of the next).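

In this assay, within the data shown here, methyl on the aromatic carbon ortho to a large group and para to the fluoro group gives a 4.0-fold lower number from compound 3 to compound 4 (0.60 log units; beyond the scatter), the first single-place change beyond the scatter. The 5-fluoro-2-methylphenyl arm also separates from the 3-methylphenyl arm, with a 4.6-fold lower number from compound 1 to compound 4 (0.67 log units; beyond the scatter), whereas the ring change in a 1.2-fold lower number from compound 1 to compound 3 (0.06 log units; within the scatter) stayed flat. Nothing available accounts for this shift.

From the compounds shown here alone, whether the step depends on the fluoro group remains open, as does whether an ethyl or chloro group on the same carbon would match methyl.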